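The compounds below may be only part of what the source reports. "The series", "measured", "known", "first", "only" and "open" are said of these compounds alone.

Measured so far:
- compound 1 `CC(C)(C)n1ncc(OCc2nnc(-c3ccc(F)cc3)o2)c(Cl)c1=O`: 2.69
- compound 2 `Cc1cccc(-c2nnc(COc3cnn(C(C)(C)C)c(=O)c3Cl)o2)c1`: 3.02

In a physicochemical assay for lipophilicity (on this read-out higher numbers stand for higher lipophilicity and lower numbers for lower lipophilicity), compound 2 gives 3.02, the higher of the two numbers; compound 1 gives 2.69. Compound 3 `CC(C)(C)n1ncc(OCc2nnc(-c3ccc(Cl)cc3F)o2)c(Cl)c1=O` differs from compound 2 in one place: 4-chloro-2-fluorophenyl in place of 3-methylphenyl on an aromatic carbon. For the measured compounds named here, the one measured step that alters the same phenyl substitution, a number 0.33 log units higher from compound 1 to compound 2 (beyond the scatter), shows a modest shift from such a swap. A step of similar size in the same direction is expected here, a number 0.33 log units higher from compound 2 to compound 3 (beyond the scatter). Compound 3 is therefore estimated at 3.35, within 3.05 to 3.65.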

Compound 3, partition coefficient: 3.23
For compound 3 the middle estimate is 0.12 log units above the measured one, within the range that was stated.
By their numbers in this assay, from the lowest: compound 1; then compounds 2 and 3 (each within the scatter of the next).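

At this position on the five-membered aromatic ring, in this assay, swapping 3-methylphenyl for 4-chloro-2-fluorophenyl gives a number 0.21 log units higher from compound 2 to compound 3 (within the scatter) and so does not separate the two groups. Swapping 4-fluorophenyl for 4-chloro-2-fluorophenyl does separate them, with a number 0.54 log units higher from compound 1 to compound 3 (beyond the scatter) as a modest step, so carrying halogen on the phenyl does not alone fix the reading. No available evidence explains either step.

Still open, on these data alone, is how a phenyl bearing a carboxylic acid or an amine would read at this position. Also open, as far as these compounds go, is whether a longer alkyl chain in place of the phenyl would keep the reading in this range.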